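The compounds below may be only part of what the source reports. "The series", "measured", "known", "first", "only" and "open" are said of these compounds alone.

Values so far in a functional assay on MV4-11 cells (Homo sapiens) for antiproliferative activity, read by resazurin assay, with a stated time of 72 h; a higher number here means a weaker inhibitor of growth, a lower number a stronger inhibitor of growth:
Compound 1 (`CC(=O)N1CCN(c2ccc(Nc3nccc(-c4c[nH]c5cccnc45)n3)cc2)CC1`) gives 420 nM
Compound 2 (`CN1CCN(c2cccc(Nc3nccc(-c4c[nH]c5cccnc45)n3)c2)CC1`) gives 405 nM
Compound 3 (`CC(=O)N1CCCN(c2cccc(Nc3nccc(-c4cnc5n(C)cccc4-5)n3)c2)CC1`) gives 24 nM

Compound 1 stands within the scatter of compound 2, while compound 3 has a lower number than compound 1, beyond the scatter. Compound 4 (`CC(=O)N1CCN(c2ccc(Nc3nccc(-c4cn(C)c5ccccc45)n3)cc2)CC1`) keeps the core of compound 1 and changes one group on the six-membered aromatic ring with 2 nitrogen, with 1-methyl-1H-indol-3-yl entering: a group of 10 heavy atoms (9 carbon, 1 nitrogen; one five-membered aromatic ring with 1 hetero atom, one six-membered aromatic ring of carbon only) in place of a group of 9 heavy atoms (7 carbon, 2 nitrogen; one five-membered aromatic ring with 1 hetero atom, one six-membered aromatic ring with 1 hetero atom), on an aromatic carbon. Among the measured compounds shown here, no measured pair isolates this change, and compound 3 differs from compound 1 in more than one place. In this assay no step beyond the scatter is expected, with a slight lean towards a higher number. The estimated step is a 1.2-fold higher number from compound 1 to compound 4 (0.08 log units; within the scatter). Compound 4 is expected at 500 nM (estimated range 120 nM to 2000 nM).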

Compound 4, concentration for 50% growth inhibition: 252 nM
The estimate for compound 4 lay 2.0-fold (0.30 log units) above the measured number, within the range that was stated.
By their numbers in this assay, from the lowest: compound 3; then compounds 4, 2 and 1 (each within the scatter of the next).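

In this assay, the step of a 1.7-fold lower number from compound 1 to compound 4 (0.22 log units; within the scatter) lies within the scatter: at this position, on an aromatic carbon of the six-membered ring with 2 nitrogen, 1-methyl-1H-indol-3-yl takes the place of the earlier group without a step beyond the scatter. Among the compounds shown here, the entering group has a six-membered aromatic ring of carbon only and 0 hydrogen-bond donors, so this pair is the first direct reading of the change at this position. No measurement on hand bears on the reason for this result. Open, going by these compounds, is how an indol-3-yl with hydrogen instead of methyl on its nitrogen, or one with an amine on its carbon ring, would read in this assay.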